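Chain extension at the sulfonyl side: compound 3 to compound 4

A few compounds are considered here, and "the series" means these few. Any claim that something is new, unique, unknown or untested is made for them only; others in the source may bear on it.

In a functional assay, read by fluorescence and spectrophotometry, with a stated time of 1 h (on this read-out lower numbers stand for an effect already at smaller amounts and higher numbers for an effect only at larger amounts of compound), compound 1 (`C=CCCCCCCCS(=O)(=O)/C=C/c1ccc(O)c(O)c1`) gives 6900 nM, compound 2 (`C=CCCCCCCS(=O)(=O)/C=C/c1ccc(O)c(O)c1`) gives 6400 nM and compound 3 (`CCCCCCS(=O)(=O)/C=C/c1ccc(O)c(O)c1`) gives 7300 nM. These three values lie within the scatter of each other, so compound 3 has no separate standing among them.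

Compound 4 (`O=S(=O)(/C=C/c1ccc(O)c(O)c1)CCCCCCCCO`) differs from compound 3 by 2-hydroxyethyl in place of hydrogen on a saturated chain carbon, six bonds along the chain from a sulfonyl sulfur. The 2-hydroxyethyl group replaces hydrogen on a saturated chain carbon, six bonds along the chain from a sulfonyl sulfur.

Three measured steps act at this same carbon: a 1.1-fold higher number from compound 1 to compound 3 (0.02 log units; within the scatter) for hydrogen in place of allyl, a 1.1-fold higher number from compound 2 to compound 3 (0.06 log units; within the scatter) for hydrogen in place of vinyl, and a 1.1-fold lower number from compound 1 to compound 2 (0.03 log units; within the scatter) for vinyl in place of allyl. All three stay within the scatter. However, no measured compound carries a 2-hydroxyethyl group, so the range is kept wide.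

No change beyond the scatter is expected in this assay, and the expected step is a 1.0-fold higher number from compound 3 to compound 4 (0.01 log units; within the scatter). Compound 4 is estimated at 7500 nM. The expected range for compound 4 runs from 3500 nM to 16000 nM.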

Compound 4, half-maximal effective concentration: 6700 nM
Compound 4: middle estimate off by 1.1-fold (0.05 log units), on the high side; low and high end bracket the measured number.
By their numbers in this assay, from the lowest: compounds 2, 4, 1 and 3 (each within the scatter of the next).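

In this assay, 2-hydroxyethyl in place of hydrogen on a saturated chain carbon, six bonds along the chain from a sulfonyl sulfur, gives a 1.1-fold lower number from compound 3 to compound 4 (0.04 log units; within the scatter); 2-hydroxyethyl in place of vinyl at that carbon gives a 1.0-fold higher number from compound 2 to compound 4 (0.02 log units; within the scatter); and hydroxymethyl in place of vinyl on a saturated chain carbon, seven bonds along the chain from a sulfonyl sulfur, gives a 1.0-fold lower number from compound 1 to compound 4 (0.01 log units; within the scatter). Among the compounds shown here, the earlier hydrogen, vinyl and allyl compounds showed only hydrocarbon ends, whereas this chain end carries a hydrogen-bond donor and acceptor and still no step leaves the scatter. No further data bear on this result.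

Going by these compounds, whether an amine, a carboxylic acid or a phenyl ring at this carbon would also stay within the scatter remains open. So does the effect of a chain longer than that of compound 1.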